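Aminopyrimidine series: microsomal stability notes

This account rests on a few compounds, and the source may have more. Where it says the series, first, only, none or still open, it means among the compounds named here.

Measured compounds:
Compound 1, `C[C@H](Nc1nc(N)nc(N)c1C#N)c1cc2ccc(F)cn2c(=O)c1-c1ccccc1`: 42%
Compound 2, `C[C@H](Nc1nc(N)ncc1C#N)c1cc2ccc(F)cn2c(=O)c1-c1ccccc1`: 11%
Compound 3, `C[C@H](Nc1ncnc(N)c1C#N)c1cc(=O)n2cc(F)ccc2c1-c1cc(F)cc(F)c1`: 57%

In an ADME assay on microsomes from liver (Mus musculus), read by LC-MS, using NADPH, with a stated time of 30 min, tested at 1 uM (a higher number here means that more of the compound is left, a lower number that less of the compound is left), compound 3 stands highest of the three measured compounds, its nearest neighbour being compound 1 and the furthest compound 2, both gaps beyond the scatter. The difference between the core of compound 2 and the core of compound 3 is not broken down here.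

Within the series one change has been measured once: amino in place of hydrogen on an aromatic carbon. That change gave a number 31 percentage points higher from compound 2 to compound 1 (beyond the scatter), a large step upward.

Compound 4, `C[C@H](Nc1nc(N)nc(N)c1C#N)c1cc(=O)n2cc(F)ccc2c1-c1cc(F)cc(F)c1`, has not yet been measured in this assay. It relates to compound 3 by the same kind of change: amino in place of hydrogen on an aromatic carbon. The surroundings of the place are not the same, however. In the step from compound 2 to compound 1 the entering amino sits next to the ring nitrogen, ortho to a cyano group and opposite the ring nitrogen; in the step from compound 3 to compound 4 it sits between two ring nitrogen atoms and para to a cyano group. The measured step is therefore only a guide of the same kind, not a copy.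

Given that compound 3 already gives 57% and that the change rests on the single step of a number 31 percentage points higher from compound 2 to compound 1 (beyond the scatter) made at a different place, a smaller upward step is expected for compound 4, a number 13 percentage points higher from compound 3 to compound 4 (beyond the scatter). The estimated value for compound 4 is 70%, with the expected range running from 50% to 88%.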

Compound 4, percent of the compound remaining: 90%
Compound 4: middle estimate off by 20 percentage points, on the low side, outside the stated range (above it).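

In this assay, amino in place of hydrogen on an aromatic carbon gave a number 33 percentage points higher from compound 3 to compound 4 (beyond the scatter), and the two available steps for this change do not differ: the same change on two cores in this assay, a number 31 percentage points higher (beyond the scatter) from compound 2 to compound 1 and a number 33 percentage points higher (beyond the scatter) from compound 3 to compound 4, 2 percentage points apart, within the scatter of two such steps

Going by these compounds alone, on these two pairs, the size of the step carries over from one core to the other, even though in compound 4 the entering amino sits between two ring nitrogen atoms and para to a cyano group, a different place from the one it takes in compound 1. This is a match across two pairs only: it does not show that the step would hold on a further core, and it gives no reason why the percentage remaining rises in either pair.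

The compounds shown leave open whether a methylamino group, a methoxy group or a chlorine atom on the same aromatic carbon would shift the percentage remaining as amino does. Within the data shown here, they also leave open how much the other differences between the core of compound 2 and the core of compound 3, including the fluorine atoms on the aryl ring of compound 3, contribute to stability, as no pair here separates them.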